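Dimethylamino for Amino on the Sulfonyl Sulfur

The source may report more compounds than this note shows. Statements on the series, on what has been measured and on what is new or still open speak of the compounds shown alone.

Compound 1 `N=S1(=O)CC(Nc2nonc2/C(=N/O)Nc2ccc(F)c(Br)c2)C1` gives 208 nM in an assay on isolated protein for inhibition of Indoleamine 2,3-dioxygenase 1 (Homo sapiens), read by fluorescence, with a stated time of 60 min; on this read-out lower numbers stand for stronger inhibition and higher numbers for weaker inhibition.
Compound 2 `NS(=O)(=O)CCCNc1nonc1/C(=N/O)Nc1ccc(F)c(Br)c1` gives 126 nM in this assay.

Among the compounds with values here, compound 2 holds the lowest of the two numbers so far, with compound 1 as its nearest neighbour: the step of a 1.7-fold lower number from compound 1 to compound 2 (0.22 log units; within the scatter) is within the scatter, so the two compounds cannot be ranked against each other on these numbers.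

Compound 3 `CN(C)S(=O)(=O)CCCNc1nonc1/C(=N/O)Nc1ccc(F)c(Br)c1` differs from compound 2 by dimethylamino in place of amino on a sulfonyl sulfur. Within the data shown here, none of the measured steps touches this part of the molecule: the one step on record, a 1.7-fold lower number from compound 1 to compound 2 (0.22 log units; within the scatter), concerns the group on the nitrogen on the aromatic ring, and it was itself within the scatter. There is therefore no measured change that bears directly on the exchange at the sulfonyl sulfur, and nothing in the two numbers points to a shift in either direction. Compound 3 is accordingly expected to land close to compound 2, with an estimated step of a 1.4-fold higher number from compound 2 to compound 3 (0.15 log units; within the scatter) that stays within the scatter. For compound 3 the estimate in this assay is 180 nM, with a range from 60 nM to 600 nM.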

Compound 3, half-maximal inhibitory concentration: 97 nM
The estimate for compound 3 lay 1.9-fold (0.27 log units) above the measured number, within the range that was stated.
By their numbers in this assay, from the lowest: compounds 3, 2 and 1 (each within the scatter of the next, the first and the last beyond it).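

In this assay, within the data shown here, dimethylamino in place of amino on the sulfonyl sulfur gives a 1.3-fold lower number from compound 2 to compound 3 (0.11 log units; within the scatter), so this is the first measured change at this place, and the hydrogen-bond donor counted on amino can go without a shift that these numbers can resolve. The place therefore accepts the two added carbon atoms of dimethylamino with no measurable loss, which neither compound 1 nor compound 2 could show alone. Among these compounds, the wider comparison, a 2.1-fold lower number from compound 1 to compound 3 (0.33 log units; beyond the scatter), is the only step so far beyond the scatter, but it is modest and replaces the whole group on the nitrogen on the aromatic ring, so it cannot be assigned to the sulfonyl sulfur or to any other single part of that group, and no measurement at hand accounts for either step.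

From the compounds shown here alone, it remains open whether methylamino, diethylamino or a larger ring amine such as morpholine on the sulfonyl sulfur would stay within the scatter of compound 3 or move the number beyond it. Also open, going by these compounds, is how a shorter or longer chain would read with dimethylamino kept on the sulfonyl sulfur.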